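A Further Methoxy on Compound 2

The compounds below may be only part of what the source reports. "The series", "measured", "known", "first", "only" and "open" are said of these compounds alone.

Compound 1 `Cc1ccc2[nH]c(-c3ccc(-c4ccc(-c5cccc(Cl)c5)cc4)cc3)nc2c1` and compound 2 `COc1ccc(-c2ccc(-c3ccc(-c4nc5cc(C)ccc5[nH]4)cc3)cc2)cc1OC` share one core and differ in a single place. In a functional assay on PC-3 cells (Homo sapiens) for inhibition, read by sulforhodamine B assay (on this read-out lower numbers stand for stronger inhibition of growth and higher numbers for weaker inhibition of growth), compound 1 gives 2670 nM and compound 2 gives 2560 nM. Going by the values given here, these two numbers are all that has been measured so far, and they stand level, so compound 2 is not set apart from its only neighbour.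

Compound 3 `COc1cc(-c2ccc(-c3ccc(-c4nc5cc(C)ccc5[nH]4)cc3)cc2)cc(OC)c1OC` differs from compound 2 by methoxy in place of hydrogen on an aromatic carbon. This is methoxy in place of hydrogen on an aromatic carbon, ortho to a methoxy group, meta to a second methoxy group and meta to a large group.

Among the compounds with values here, only one measured step bears on this change: a 1.0-fold lower number from compound 1 to compound 2 (0.02 log units; within the scatter), with 3,4-dimethoxyphenyl in place of 3-chlorophenyl on an aromatic carbon. Within the data shown here, that is thin evidence, since no measured pair shows methoxy replacing hydrogen. On that single step, no shift beyond the scatter is expected in this assay. The estimated step is a 1.1-fold lower number from compound 2 to compound 3 (0.03 log units; within the scatter). For compound 3 the expected value is 2400 nM, with an estimated range of 1100 nM to 5500 nM.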

Compound 3, concentration for 50% growth inhibition: 180 nM
Beside the measured number, compound 3's estimate is 13-fold (1.12 log units) above it, outside the stated range (below it).
By their numbers in this assay, from the lowest: compound 3; then compounds 2 and 1 (each within the scatter of the next).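

In this assay, methoxy in place of hydrogen on an aromatic carbon, ortho to a methoxy group, meta to a second methoxy group and meta to a large group, gives a 14-fold lower number from compound 2 to compound 3 (1.15 log units; beyond the scatter), a large step well beyond the scatter. The earlier pair showed no such movement, since a 1.0-fold lower number from compound 1 to compound 2 (0.02 log units; within the scatter) left the two numbers level, so this is the first change among the compounds shown that shifts growth inhibition, and it shows that this ring can respond strongly to one added methoxy even though exchanging 3-chlorophenyl for 3,4-dimethoxyphenyl did not. Nothing measured here accounts for the size of this step.

The compounds shown leave open whether another group at this same place, such as a hydroxyl, an ethoxy or an amine, would give a step of similar size. They also leave open whether the step depends on the two methoxy groups already on the ring, or whether the added methoxy would have the same effect without them.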